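Chlorophenyl carbinols in a cell-based inhibition assay

A few compounds are considered here, and "the series" means these few. Any claim that something is new, unique, unknown or untested is made for them only; others in the source may bear on it.

Measured so far:
compound 1 `OC(c1ccccc1)(c1ccccc1)c1ccccc1Cl`: 31%
compound 2 `OC(Cc1ccccc1)(c1ccccc1)c1ccccc1`: 98%; 98% (2 entries)

Among the measured compounds shown here, in a functional assay on NIH3T3 cells (Mus musculus) for inhibition, tested at 10 uM (a higher number here means more inhibition at the concentration tested (going by the name of the read-out), a lower number less inhibition), compound 1 gives 31%; this is the only numbered result for compound 1, with one further entry that carries no single number. Compound 2 gives 98%; 98% (2 entries) in both of its entries, clearly above compound 1. For the measured compounds named here, no single-change step between measured compounds is available. Compound 3 `OC(c1ccccc1)(c1ccccc1)c1ccc(Cl)cc1` differs from compound 1 by 4-chlorophenyl in place of 2-chlorophenyl on a saturated chain carbon bound to two aromatic carbons and an oxygen on a saturated carbon. Nothing measured shows what such a move does, so the expected step is a number 14 percentage points higher from compound 1 to compound 3 (beyond the scatter), possibly within the scatter. Compound 3 is expected to give 45%, within 15% to 85%.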

Compound 3, a percentage reported as inhibition, at one concentration (the size of the read-out at that concentration, not a potency): 99%
For compound 3 the middle estimate is 54 percentage points below the measured one; the measured number lies above the stated range.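

In this assay, 4-chlorophenyl in place of 2-chlorophenyl on this saturated chain carbon gives a number 68 percentage points higher from compound 1 to compound 3 (beyond the scatter). Among the compounds shown here, the two compounds have the same atoms, joined differently, so this is the first single-change pair, and it shows that the read-out is highly sensitive to where the chlorine sits on this ring. Nothing measured on these compounds explains the step.

Still open, from the compounds shown here alone, is whether 4-fluorophenyl or 4-methoxyphenyl at this place would hold the read-out. Going by these compounds, the effect of an amine in place of the hydroxyl also remains unknown.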